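Swapping a Pyridine Arm for a Tolyl Group

The compounds below may be only part of what the source reports. "The series", "measured", "known", "first", "only" and "open" are said of these compounds alone.

Compound 1 `CNC(=O)c1cc(C(=O)N[C@H]2[C@@H]3COC[C@@H]32)cc2c1OC[C@H]2c1ccccn1` is one of three close relatives that have been measured in a physicochemical assay for solubility; on this read-out lower numbers stand for lower solubility and higher numbers for higher solubility. In this assay compound 1 gives >= 158 ug/mL, which is a limit of the measurement rather than a number. Compound 1 therefore stands at the limit of >= 158 ug/mL in this assay, at which 1 of the 3 values shown sits. Compound 2 `CNC(=O)c1cc(C(=O)N[C@H]2C[C@@H]2C)cc2c1OC[C@@]2(CO)c1ccccc1` gives in this assay a reading of >= 229 ug/mL, again a limit. Compound 3 `CNC(=O)c1cc(C(=O)N[C@H]2[C@@H]3COC[C@@H]32)cc2c1O[C@H](CF)[C@H]2c1ccccc1` gives in this assay a reading of >= 206 ug/mL, also a limit. Among the compounds with values here, no two of these three differ in only one place, so no measured step can be drawn from them; what they show is that each sits at a limit of the assay.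

Compound 4 `CNC(=O)c1cc(C(=O)N[C@H]2[C@@H]3COC[C@@H]32)cc2c1OC[C@H]2c1ccccc1C` has not yet been measured in this assay. It differs from compound 1 by 2-methylphenyl in place of pyridin-2-yl on a saturated ring carbon. Within the data shown here, with no measured step to lean on, the step of an at least 2.6-fold lower number from compound 1 to compound 4 (0.42 log units; beyond the scatter) is expected to be a moderate drop, beyond the usual scatter. In this assay compound 4 is estimated at 60 ug/mL, most likely falling between 15 ug/mL and 200 ug/mL.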

Compound 4, solubility: >= 103 ug/mL
Compound 4 gave a limit, no number; the forecaster's own chance of this, stated with the estimate: 25%; middle value at least 1.7-fold (0.23 log units) from the limit.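

Compound 1 and compound 4 each gave a limit rather than a number in this assay, and the step between them cannot be read. The compounds shown leave open whether 2-methylphenyl in place of pyridin-2-yl on a saturated ring carbon changes this reading at all.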